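Series notes: chain-linked versus directly attached phenyl group

A few compounds are considered here, and "the series" means these few. Any claim that something is new, unique, unknown or untested is made for them only; others in the source may bear on it.

Of the compounds shown here, three sharing one core have been measured in a functional assay on HeLa cells (Homo sapiens) for inhibition, read by cell counting, with a stated time of 4 days; a lower number here means a stronger inhibitor, a higher number a weaker inhibitor. Compound 1 `C=C(Br)C(=O)Nc1cccc(-c2cn3nc(-c4ccc(F)cc4)sc3n2)c1` gives 870 nM and stands lowest. Compound 2 `C=C(Br)C(=O)Nc1cccc(-c2cn3nc(Cc4ccc(Cl)cc4)sc3n2)c1` gives 2700 nM. Compound 3 `C=C(Br)C(=O)Nc1cccc(-c2cn3nc(-c4ccc(C)cc4)sc3n2)c1` gives 2000 nM, the second highest of the three numbers; its nearest neighbour is compound 2, which lies within the scatter of it, while compound 1 lies beyond the scatter below it.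

Compound 4 `C=C(Br)C(=O)Nc1cccc(-c2cn3nc(CCc4ccccc4)sc3n2)c1` remains to be measured. Relative to compound 3 the change is phenethyl in place of 4-methylphenyl on an aromatic carbon, so a phenyl group attached through a two-carbon chain replaces a phenyl group attached directly, as the 4-methylphenyl was.

Going by the values given here, two measured steps bear on this. The most direct one is a 1.4-fold lower number from compound 2 to compound 3 (0.13 log units; within the scatter), where a chain-linked phenyl group and a directly attached one gave numbers within the scatter of each other. The second is a 3.1-fold higher number from compound 1 to compound 2 (0.49 log units; beyond the scatter), a modest rise when a chain-linked group replaced a directly attached one, though that step also exchanged the ring substituent. Taken together, little or at most a modest rise in this assay is expected for compound 4.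

Compound 4 is therefore estimated at 3500 nM, with a range of 1500 nM to 9000 nM, meaning an expected step of a 1.8-fold higher number from compound 3 to compound 4 (0.24 log units; within the scatter).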

Compound 4, half-maximal inhibitory concentration: 3300 nM
For compound 4 the middle estimate is 1.1-fold (0.03 log units) above the measured one; low and high end bracket the measured number.
By their numbers in this assay, from the lowest: compound 1; then compounds 3, 2 and 4 (each within the scatter of the next).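

Phenethyl at this position, on the aromatic carbon next to the ring nitrogen and the ring sulfur, adds a third group to the cluster: in this assay there is a 1.7-fold higher number from compound 3 to compound 4 (0.22 log units; within the scatter) and a 1.2-fold higher number from compound 2 to compound 4 (0.09 log units; within the scatter), so a phenyl ring without a substituent on a two-carbon chain cannot be told apart from the directly attached 4-methylphenyl or from the 4-chlorobenzyl group of compound 2. The separation that remains concerns compound 1 alone, with a 3.8-fold higher number from compound 1 to compound 4 (0.58 log units; beyond the scatter), yet the length of the link does not account for the series as a pattern, since the directly attached 4-methylphenyl of compound 3 goes against it by sitting within the scatter of both chain-linked compounds. No measurement at hand offers an explanation for these numbers.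

In compound 4 the link and the ring substituent differ together from compound 3, so the contribution of each stays unresolved, and a directly attached phenyl without a substituent or a 4-fluorophenethyl group would separate them. As far as these compounds go, whether the position also accepts a longer chain, or an amine or a carboxylic acid on the chain, remains open.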